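The source may hold more compounds than are shown below. What is called first, only, known or untested is meant among the compounds shown, and "the series" means these compounds.

In a functional assay on A2780 cells (Homo sapiens) for cytotoxicity, read by MTT assay, with a stated time of 24 h (on this read-out higher numbers stand for weaker inhibition and lower numbers for stronger inhibition), compound 1 (`CCCCC[C@@H](C[C@H](O)C[C@@H]1CC=CC(=O)O1)OC`) gives 35400 nM and compound 2 (`CCCCC[C@@H](C[C@@H](O)C[C@H]1CC=CC(=O)O1)OC`) gives 33700 nM. Compound 2 therefore stands level with compound 1, and the step between them is a 1.1-fold lower number from compound 1 to compound 2 (0.02 log units; within the scatter). Compound 3 (`CCCCC[C@H](C[C@H](O)C[C@@H]1CC=CC(=O)O1)OC`) has not yet been measured. Its relation to compound 2 is this: the two compounds have the same atoms and bonds and differ only in configuration as drawn: 3 of 3 stereo elements differ (all stereocentres are inverted: mirror images); a stereocentre at a saturated chain carbon is drawn S in compound 2 and R in compound 3; a stereocentre at a saturated chain carbon is drawn R in compound 2 and S in compound 3; a stereocentre at a saturated ring carbon is drawn R in compound 2 and S in compound 3. The only measured step bears on this change, since it too alters configuration alone, as shown by the fact that compounds 1 and 2 differ only in the configuration as drawn. From the compounds shown here alone, that step, at a saturated chain carbon and a saturated ring carbon, stayed within the scatter, but full inversion to the mirror image remains untested. No step beyond the scatter is therefore expected in this assay, in either direction. The expected change is a 1.0-fold higher number from compound 2 to compound 3 (0.00 log units; within the scatter). Compound 3 is estimated at 34000 nM, with an expected range from 17000 nM to 68000 nM.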

Compound 3, half-maximal inhibitory concentration: 22900 nM
Estimate against measurement, compound 3: 1.5-fold (0.17 log units) above; the measured number falls inside the stated range.
By their numbers in this assay, from the lowest: compounds 3, 2 and 1 (each within the scatter of the next).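

In this assay, for the compounds shown here, full inversion to the mirror image, which no earlier step had covered, gives a 1.5-fold lower number from compound 2 to compound 3 (0.17 log units; within the scatter), so this step stays within the scatter and the read-out does not separate this mirror-image pair. Changing a single stereocentre at a saturated chain carbon, which the earlier step had changed only together with a ring stereocentre, gives a 1.5-fold lower number from compound 1 to compound 3 (0.19 log units; within the scatter), also within the scatter. Among these three compounds, then, no step involving configuration alone goes beyond the scatter: the fact that compounds 2 and 3 differ only in the configuration as drawn

The compounds shown leave open whether inverting the saturated ring carbon alone would behave in the same way. Since all three share the same atoms and bonds, they also do not show how the number would respond to an amine in place of the hydroxyl, or to a longer chain.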